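Sulfamoyl for benzoyl on the amine nitrogen of compound 2

The source may report more compounds than this note shows. Statements on the series, on what has been measured and on what is new or still open speak of the compounds shown alone.

Compound 1 `O=C(Nc1ccccc1)[C@H]1CC[C@H](C(=O)/C(=N/O)Nc2ccc(F)c(Br)c2)CC1` and compound 2 `O=C(NC[C@H]1CC[C@H](C(=O)/C(=N/O)Nc2ccc(F)c(Br)c2)CC1)c1ccccc1` share a core and differ in one place. In an assay for inhibition of Indoleamine 2,3-dioxygenase 1 (Homo sapiens), with a stated time of 1 h (a higher number here means a weaker inhibitor, a lower number a stronger inhibitor), compound 1 gives 150 nM, and compound 2 gives 80 nM. Going by the values given here, the single measured step, a 1.9-fold lower number from compound 1 to compound 2 (0.27 log units; within the scatter), leaves compound 2 with the lowest of the two numbers, but its gap to compound 1 lies within the scatter, so no order between them is claimed. Compound 3 `NS(=O)(=O)NC[C@H]1CC[C@H](C(=O)/C(=N/O)Nc2ccc(F)c(Br)c2)CC1` carries sulfamoyl in place of benzoyl on an amine nitrogen. Among the compounds with values here, no measured pair shows this swap; the step from compound 1 to compound 2 changed the group on a saturated ring carbon rather than the benzoyl, so it bears only indirectly on the present change, and it was itself small. Within the data shown here, with no closer analogue, no step beyond the scatter is assumed in either direction. Compound 3 is therefore expected near 120 nM in this assay, within a range from 40 nM to 400 nM. The expected step is a 1.5-fold higher number from compound 2 to compound 3 (0.18 log units; within the scatter).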

Compound 3, half-maximal inhibitory concentration: 198 nM
Compound 3: the middle estimate sits 1.7-fold (0.22 log units) below what was measured; the range from low to high includes it.
By their numbers in this assay, from the lowest: compounds 2, 1 and 3 (each within the scatter of the next, the first and the last beyond it).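

In this assay, the amine nitrogen carrying benzoyl in compound 2 also accepts sulfamoyl, a group with no ring, at a modest cost: a 2.5-fold higher number from compound 2 to compound 3 (0.39 log units; beyond the scatter). The aromatic ring of the benzoyl is therefore not needed for inhibition to remain measurable, although this single pair cannot show how much of the step comes from its removal and how much from the sulfamoyl group. The other listed comparison, a 1.3-fold higher number from compound 1 to compound 3 (0.12 log units; within the scatter), gives no order between those two compounds, and no data on hand speak to the origin of either step.

The compounds shown leave open whether the step follows from losing the ring or from the sulfamoyl group itself. An acetyl or a methanesulfonyl on the same amine nitrogen would help separate those two readings.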